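A few compounds are considered here, and "the series" means these few. Any claim that something is new, unique, unknown or untested is made for them only; others in the source may bear on it.

Measured compounds and their values in a functional assay on PC-3 cells (Homo sapiens) for antiproliferative activity, read by WST assay, with a stated time of 3 days; a lower number here means a stronger inhibitor, a higher number a weaker inhibitor

Compound 1 `CCCCOc1c(-c2cc(OC)c(OC)c(OC)c2)oc2ccccc2c1=O` gives 12800 nM
Compound 2 `CCCCCOc1c(-c2cc(OC)c(OC)c(OC)c2)oc2ccccc2c1=O` gives 22200 nM
Compound 3 `CCCCCCOc1c(-c2cc(OC)c(OC)c(OC)c2)oc2ccccc2c1=O` gives 29200 nM

Compound 3 stands at 29200 nM and cannot be told apart from its nearest neighbour, the measured step being a 1.3-fold higher number from compound 2 to compound 3 (0.12 log units; within the scatter) and no more. Only the widest gap in the series exceeds the scatter, at a 2.3-fold higher number from compound 1 to compound 3 (0.36 log units; beyond the scatter) and this is modest. The remaining step is a 1.7-fold higher number from compound 1 to compound 2 (0.24 log units; within the scatter) and it too gives no clear separation.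

Compound 4 `CCCC(C)Oc1c(-c2cc(OC)c(OC)c(OC)c2)oc2ccccc2c1=O` carries 1-methylbutyl in place of hexyl on an oxygen on an aromatic ring. Going by the values given here, no branched chain has been measured, so the straight chains are the only guide. These steps suggest a small change in this assay at most, towards a lower number. The expected step is a 1.6-fold lower number from compound 3 to compound 4 (0.21 log units; within the scatter) and it is not expected to clearly exceed the scatter. The estimated value for compound 4 is 18000 nM with an expected range (9000 nM to 35000 nM).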

Compound 4, half-maximal inhibitory concentration: 49300 nM
Beside the measured number, compound 4's estimate is 2.7-fold (0.44 log units) below it, and the stated range ends below it.
By their numbers in this assay, from the lowest: compounds 1, 2, 3 and 4 (each within the scatter of the next, the first and the last beyond it).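

In this assay, the branched chain cannot be separated from hexyl, with a 1.7-fold higher number from compound 3 to compound 4 (0.23 log units; within the scatter), but it does separate from the two other straight chains, with a 2.2-fold higher number from compound 2 to compound 4 (0.35 log units; beyond the scatter) and a 3.9-fold higher number from compound 1 to compound 4 (0.59 log units; beyond the scatter), both modest. Going by these compounds alone, this is the first sign that the carbon bound to the oxygen on the aromatic ring matters, as the straight chains only ever varied further out. Methyl in place of hydrogen does not give one fixed step along this chain, and the step at that carbon is the larger: the same change on two cores in this assay, a 1.3-fold higher number (0.12 log units; within the scatter) from compound 2 to compound 3 and a 3.9-fold higher number (0.59 log units; beyond the scatter) from compound 1 to compound 4, 2.9-fold (0.47 log units) apart, beyond the scatter of two such steps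

The compounds shown leave open whether a shorter chain such as ethyl or propyl would give a lower number, and whether a branch further out, as in 3-methylbutyl, would behave like the straight chains. They also do not show what an amine or a carboxylic acid at the end of the chain would do.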